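A few compounds are considered here, and "the series" means these few. Any claim that something is new, unique, unknown or untested is made for them only; others in the source may bear on it.

In a functional assay on T47D cells (Homo sapiens) for inhibition, read by sulforhodamine B assay, with a stated time of 48 h (a lower number here means a stronger inhibitor of growth, a higher number a weaker inhibitor of growth), the three measured compounds are:

compound 1, `CC(=O)OC/C(=C\C1CCCCC1)C(=O)c1ccccc1`: 22000 nM
compound 2, `CCC(/C=C(\COC(C)=O)C(=O)c1ccccc1)CC`: 89000 nM
compound 3, `CC(=O)OC/C(=C\c1ccc(Cl)cc1)C(=O)c1ccccc1`: 5300 nM

Compound 3 stands lowest of the three in this assay. Its nearest neighbour is compound 1, and the step of a 4.2-fold lower number from compound 1 to compound 3 (0.62 log units; beyond the scatter) is modest, whereas the step of a 17-fold lower number from compound 2 to compound 3 (1.23 log units; beyond the scatter) is large. Between the other two, the step of a 4.0-fold higher number from compound 1 to compound 2 (0.61 log units; beyond the scatter) is also beyond the scatter.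

Compound 4 is `CC(=O)OC/C(=C\c1ccc(F)cc1)C(=O)c1ccccc1`. The change from compound 3 is fluoro in place of chloro on an aromatic carbon. Within the data shown here, none of the measured steps touches this position: each of them exchanges the whole group on the double-bonded chain carbon, cyclohexyl, pentan-3-yl or 4-chlorophenyl, and no pair differs only in a substituent on the aromatic ring. The measured steps therefore show how much the identity of that group matters, but give no direct guide to a single halogen swap on it. The 4-chlorophenyl compound gives the lowest number, and the change to fluoro keeps the aromatic ring and its para substitution in place, so a step of modest size at most is expected, in the direction of a somewhat higher number, as a 1.7-fold higher number from compound 3 to compound 4 (0.23 log units; within the scatter). Compound 4 is accordingly expected to give about 9000 nM in this assay, with a range from 3500 nM to 25000 nM.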

Compound 4, concentration for 50% growth inhibition: 14000 nM
Compound 4: the middle estimate sits 1.6-fold (0.19 log units) below what was measured; the range from low to high includes it.
By their numbers in this assay, from the lowest: compound 3; then compounds 4 and 1 (each within the scatter of the next); then compound 2.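

In this assay, among these compounds, the substituent on this aromatic carbon proves to matter in its own right: with a 2.6-fold higher number from compound 3 to compound 4 (0.42 log units; beyond the scatter), the exchange of a single halogen para to a large group moves the number beyond the scatter, which the earlier steps could not show because each replaced the whole group on the double-bonded chain carbon. The aromatic ring alone does not set compound 4 apart from the cyclohexyl compound, since a 1.6-fold lower number from compound 1 to compound 4 (0.20 log units; within the scatter) lies within the scatter, whereas the 4-chlorophenyl group of compound 3 did stand apart from cyclohexyl. Against the open-chain pentan-3-yl group, the 4-fluorophenyl group still makes a difference beyond the scatter, with a 6.4-fold lower number from compound 2 to compound 4 (0.80 log units; beyond the scatter) giving a second case of an aromatic group with a lower number than that chain.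

No measurement at hand accounts for the difference between chloro and fluoro at this carbon. The compounds shown leave open what bromo, methoxy, an amine or plain hydrogen would give at this same aromatic carbon, and whether the chloro to fluoro step would keep its size with a hydroxyl group in place of the acetate.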